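Aryl variation on the triazole nitrogen: estimating compound 4

A few compounds are considered here, and "the series" means these few. Any claim that something is new, unique, unknown or untested is made for them only; others in the source may bear on it.

compound 1 `CC1(C)[C@H]2CC[C@]1(C)N(Cc1cn(-c3cccc(Cl)c3)nn1)C(=O)C2`: 60 nM in a functional assay on A549 cells (Homo sapiens) for inhibition, read by MTT assay, with a stated time of 24 h; on this read-out lower numbers stand for stronger inhibition and higher numbers for weaker inhibition
compound 2 `CC1(C)[C@H]2CC[C@]1(C)N(Cc1cn(-c3ccc(Cl)cc3)nn1)C(=O)C2`: 70 nM in this assay
compound 3 `Cc1ccccc1-n1cc(CN2C(=O)C[C@@H]3CC[C@@]2(C)C3(C)C)nn1`: 90 nM in this assay

Compound 3 carries the highest of the three numbers, yet neither gap is meaningful: a 1.3-fold higher number from compound 2 to compound 3 (0.11 log units; within the scatter) and a 1.5-fold higher number from compound 1 to compound 3 (0.18 log units; within the scatter) both fall within the scatter. Compound 4 `COc1ccc(-n2cc(CN3C(=O)C[C@@H]4CC[C@@]3(C)C4(C)C)nn2)cc1` differs from compound 3 by 4-methoxyphenyl in place of 2-methylphenyl on an aromatic nitrogen. Every measured step in this set is a swap of the aryl group on the same aromatic nitrogen, and all three lie within the scatter: a 1.2-fold higher number from compound 1 to compound 2 (0.07 log units; within the scatter), a 1.5-fold higher number from compound 1 to compound 3 (0.18 log units; within the scatter), a 1.3-fold higher number from compound 2 to compound 3 (0.11 log units; within the scatter). Going by the values given here, no measured pair involves a 4-methoxyphenyl group, so the expectation rests on these three swaps alone. The step to compound 4 is therefore expected to be no change at the digits printed from compound 3 to compound 4 (within the scatter), no shift beyond the scatter. In this assay compound 4 is estimated at 90 nM, within 45 nM to 200 nM.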

Compound 4, half-maximal inhibitory concentration: 50 nM
For compound 4 the middle estimate is 1.8-fold (0.26 log units) above the measured one, within the range that was stated.
By their numbers in this assay, from the lowest: compounds 4, 1, 2 and 3 (each within the scatter of the next).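

A 4-methoxyphenyl group on the aromatic nitrogen, which adds a hydrogen-bond acceptor to the aryl substituent, gives no change beyond the scatter in this assay: a 1.8-fold lower number from compound 3 to compound 4 (0.26 log units; within the scatter), a 1.4-fold lower number from compound 2 to compound 4 (0.15 log units; within the scatter) and a 1.2-fold lower number from compound 1 to compound 4 (0.08 log units; within the scatter). Across the four compounds, the aryl swaps at this position have not yet produced a step beyond the scatter. No available data bear on a cause for this closeness.

Still open, going by these compounds, is whether an aryl group bearing an amine or a carboxylic acid would separate from this cluster. On these data alone, a longer alkyl chain in place of the aryl group on the same nitrogen is equally open.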